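The compounds below may be only part of what the source reports. "The series", "measured", "known", "first", "only" and "open" are said of these compounds alone.

In a functional assay on MCF7 cells (Homo sapiens) for cytotoxicity, read by sulforhodamine B assay, with a stated time of 48 h (on this read-out lower numbers stand for stronger inhibition and higher numbers for weaker inhibition), compound 1 `N#C/C(C(=O)Nc1ccccc1)=c1/s/c(=C\c2ccccc2)c(=O)n1-c1ccccc1` gives 75300 nM, compound 2 `N#C/C(C(=O)Nc1ccccc1)=c1/s/c(=C\c2ccccc2O)c(=O)n1-c1ccccc1` gives 8850 nM and compound 3 `N#C/C(C(=O)Nc1ccc(Cl)cc1)=c1/s/c(=C\c2ccccc2)c(=O)n1-c1ccccc1` gives 77500 nM. Compound 3 has the highest of the three numbers; its gap to compound 1 lies within the scatter, its gap to compound 2 beyond it. Compound 4 `N#C/C(C(=O)Nc1ccc(Cl)cc1)=c1/s/c(=C\c2ccc(Cl)cc2)c(=O)n1-c1ccccc1` differs from compound 3 by chloro in place of hydrogen on an aromatic carbon. Among the measured compounds shown here, two measured steps bear on this. The same entering group, chloro, appears in a 1.0-fold higher number from compound 1 to compound 3 (0.01 log units; within the scatter), a step within the scatter. For the measured compounds named here, the one step beyond the scatter, an 8.5-fold lower number from compound 1 to compound 2 (0.93 log units; beyond the scatter), brought in a different group, hydroxy. With chloro entering here, no movement beyond the scatter is expected in this assay, the step being estimated as a 1.3-fold lower number from compound 3 to compound 4 (0.11 log units; within the scatter). Compound 4 is expected to give 60000 nM, within 20000 nM to 150000 nM.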

Compound 4, half-maximal inhibitory concentration: > 101000 nM
Compound 4: only a limit was reported; the forecaster's own chance of this, stated with the estimate: 10%; middle value at least 1.6-fold (0.22 log units) away from the limit.
By their numbers in this assay, from the lowest: compound 2; then compounds 1 and 3 (each within the scatter of the next). At a limit, above all of these: compound 4.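

Chloro on the anilide ring was the only chloro shown before; here it enters the ring that carries hydroxy in compound 2, as phenyl to 4-chlorophenyl, giving an at least 1.3-fold higher number from compound 3 to compound 4 (0.11 log units; that floor lies within the scatter). In this assay compound 4 is reported only as a limit: the limit of > 101000 nM in this assay, at which 1 of the 4 values shown sits. Its floor lies within the scatter, so the size of the step stays unread, but this chloro does not reproduce the lower number seen with hydroxy, an 8.5-fold lower number from compound 1 to compound 2 (0.93 log units; beyond the scatter).

Open, from the compounds shown here alone, is whether the hydroxy step depends on its place on that ring. Also open, going by these compounds, is whether an amine or a methoxy group there would follow hydroxy or chloro.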